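Swapping the imidazole for a methylated pyrazolylamino group

The source may report more compounds than this note shows. Statements on the series, on what has been measured and on what is new or still open speak of the compounds shown alone.

Of the compounds shown here, three have been measured in a physicochemical assay for solubility, read by LC-MS, in phosphate buffer, with a stated time of 24 h, at pH 7.4; on this read-out higher numbers stand for higher solubility and lower numbers for lower solubility. Compound 1 `Cc1nccn1-c1cnc(NCc2c(F)ccc3c2CCO3)c2cn[nH]c(=O)c12` gives 7000 nM. Compound 2 `Cc1ncccc1-c1cnc(NCc2c(F)ccc3c2CCO3)c2ncc(=O)[nH]c12`, built on a different core, gives 29000 nM. Compound 3 `Cc1ncccc1-c1cnc(NCc2c(F)ccc3c2CCO3)n2c(=O)[nH]nc12`, on yet another core, reports only the limit of this assay, < 2000 nM, which sits at the limit of < 2000 nM in this assay, at which 1 of the 3 values shown sits. Among the two real numbers, compound 1 stands lowest, and the gap up to compound 2 lies beyond the usual scatter.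

The step of interest leads from compound 1 to the unmeasured compound 4 `CN(c1ccn(C)n1)c1cnc(NCc2c(F)ccc3c2CCO3)c2cn[nH]c(=O)c12`. The two structures differ in one place: methyl(1-methyl-1H-pyrazol-3-yl)amino in place of 2-methyl-1H-imidazol-1-yl on an aromatic carbon. Both compounds keep the shared core of compound 1 and the same side chain on the other part of the ring system.

Among the compounds with values here, because no two of the measured compounds differ in a single place, no measured step shows how a change of this kind moves solubility here, and the three values rest on three different cores. The expectation for the step from compound 1 to compound 4 is therefore modest, with no change beyond the scatter in either direction, as given by no change at the digits printed from compound 1 to compound 4 (within the scatter). On that basis compound 4 is estimated to give 7000 nM, with a likely range from 2500 nM to 20000 nM.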

Compound 4, solubility: 12000 nM
The estimate for compound 4 lay 1.7-fold (0.23 log units) below the measured number; the range from low to high includes it.
By their numbers in this assay, from the lowest: compounds 1 and 4 (each within the scatter of the next); then compound 2. At a limit, below all of these: compound 3.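

The exchange of 2-methyl-1H-imidazol-1-yl for methyl(1-methyl-1H-pyrazol-3-yl)amino on this aromatic carbon gives, in this assay, a 1.7-fold higher number from compound 1 to compound 4 (0.23 log units; within the scatter). Within the data shown here, this is the first pair in the set that differs in one place, so it gives the first direct reading for this position, free of any change of core: on the shared core of compound 1, a larger group joined through an amino nitrogen leaves the solubility reading within the scatter of the reading for the imidazole. Nothing measured here offers an explanation for how the two groups compare.

The compounds shown leave open whether a group with no aromatic ring at this position, such as a dimethylamino group or a morpholine, or a group carrying a carboxylic acid, would move the reading beyond the scatter. They also leave open whether the same exchange of groups would read the same way on the core of compound 2, where the pyridine-bearing parent has a different group at the matching place.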